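The compounds below may be only part of what the source reports. "The series", "measured", "known", "first", "only" and "open" are said of these compounds alone.

Three compounds that share a stilbene-like core with a fluorinated double bond have been measured in a functional assay on cells (Endothelial cell, Bos taurus) for antiproliferative activity; on this read-out lower numbers stand for stronger inhibition and higher numbers for weaker inhibition. Compound 1 `COc1ccc(/C=C(/F)c2cc(OC)c(OC)c(OC)c2)cc1N` gives 2000 nM. Compound 3 `COc1ccc(/C=C(/F)c2cc(OC)c(OC)c(OC)c2)cc1[N+](=O)[O-]` gives 38400 nM. Compound 2 `COc1ccc(/C(F)=C(\F)c2cc(OC)c(OC)c(OC)c2)cc1[N+](=O)[O-]` gives 2300000 nM, the highest of the three. Going from compound 3 to compound 1, the change is amino in place of nitro on an aromatic carbon, and this brought a 19-fold lower number from compound 3 to compound 1 (1.28 log units; beyond the scatter). The difference between the cores of compound 2 and compound 3 is not broken down here. Compound 4 `COc1ccc(/C(F)=C(\F)c2cc(OC)c(OC)c(OC)c2)cc1N` is not yet measured; it differs from compound 2 by amino in place of nitro on an aromatic carbon, the same change at the same place. If that step carries over, the number is expected to move by about a 15-fold lower number from compound 2 to compound 4 (1.19 log units; beyond the scatter) from compound 2 to compound 4, resting on compound 3 to compound 1. Compound 4 is therefore estimated at 150000 nM, likely between 30000 nM and 700000 nM.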

Compound 4, half-maximal inhibitory concentration: 204000 nM
Beside the measured number, compound 4's estimate is 1.4-fold (0.13 log units) below it; low and high end bracket the measured number.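

Putting amino in place of nitro on the second core gave an 11-fold lower number from compound 2 to compound 4 (1.05 log units; beyond the scatter), so in this assay the change kept its direction when carried from one core to the other. The two steps also agree in size once the usual scatter is allowed for: the same change on two cores in this assay, a 19-fold lower number (1.28 log units; beyond the scatter) from compound 3 to compound 1 and an 11-fold lower number (1.05 log units; beyond the scatter) from compound 2 to compound 4, 1.7-fold (0.23 log units) apart, within the scatter of two such steps. This rests on just two pairs of compounds, so it does not show that the step would hold on any further core, and it does not explain why the amino compounds give the lower numbers.

The compounds shown leave open how other groups on the same aromatic carbon, such as a hydroxyl or an acetamide, would compare with amino and nitro. They also leave open whether a core with no fluorine on the double bond would show a similar step.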